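Moving a Methyl Around the Imidazole

This account rests on a few compounds, and the source may have more. Where it says the series, first, only, none or still open, it means among the compounds named here.

Among the three measured compounds, compound 3 `CCCn1cnc(CN2CCN(c3cccc4[nH]c(-c5ccc(C(C)(C)C)cc5)nc34)CC2)c1C` stands lowest in an assay on isolated protein for displacement of a labelled ligand from Gonadotropin-releasing hormone receptor (Homo sapiens) (a higher number here means a weaker inhibitor, a lower number a stronger inhibitor), giving 12 nM. Compound 1 `Cn1cnc(CN2CCN(c3cccc4[nH]c(-c5ccc(C(C)(C)C)cc5)nc34)CC2)c1` gives 33 nM in this assay, and compound 2 `Cc1nc(C)c(CN2CCN(c3cccc4[nH]c(-c5ccc(C(C)(C)C)cc5)nc34)CC2)o1` gives 31 nM. The step of a 1.1-fold lower number from compound 1 to compound 2 (0.03 log units; within the scatter) shows that swapping one heteroaryl group for another can leave the number essentially unchanged, whereas a 2.8-fold lower number from compound 1 to compound 3 (0.44 log units; beyond the scatter) and a 2.6-fold lower number from compound 2 to compound 3 (0.41 log units; beyond the scatter) show modest gains on moving to the 5-methyl-1-propyl-1H-imidazol-4-yl group.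

Compound 4 `CCCn1cc(CN2CCN(c3cccc4[nH]c(-c5ccc(C(C)(C)C)cc5)nc34)CC2)nc1C` differs from compound 3 only in that (2-methyl-1-propyl-1H-imidazol-4-yl in place of 5-methyl-1-propyl-1H-imidazol-4-yl on a saturated chain carbon bound to an amine nitrogen in a ring). For the measured compounds named here, none of the measured steps moves a methyl from one position to another on the same ring, so the closest guidance comes from the modest sizes of a 2.8-fold lower number from compound 1 to compound 3 (0.44 log units; beyond the scatter) and a 2.6-fold lower number from compound 2 to compound 3 (0.41 log units; beyond the scatter), which together suggest that changes on this heteroaryl group shift the number by modest amounts at most. Compound 4 is therefore expected to give 18 nM in this assay, with a range of 6 nM to 55 nM, corresponding to an expected step of a 1.5-fold higher number from compound 3 to compound 4 (0.18 log units; within the scatter), likely within the scatter.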

Compound 4, half-maximal inhibitory concentration: 18 nM
Compound 4: middle estimate and measured number agree at the digits printed; low and high end bracket the measured number.
By their numbers in this assay, from the lowest: compounds 3, 4, 2 and 1 (each within the scatter of the next, the first and the last beyond it).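

In this assay a 1.5-fold higher number from compound 3 to compound 4 (0.18 log units; within the scatter) is the first step shown that keeps the same atoms and only joins them differently, and it shows that 2-methyl-1-propyl-1H-imidazol-4-yl can stand in place of 5-methyl-1-propyl-1H-imidazol-4-yl with no change that this read-out can resolve. Unlike compound 3, compound 4 is not separated from the two smaller heteroaryl groups: a 1.7-fold lower number from compound 2 to compound 4 (0.24 log units; within the scatter) and a 1.8-fold lower number from compound 1 to compound 4 (0.26 log units; within the scatter) both stay within the scatter, so the modest gain at this position holds for only one of the two methyl placements. Nothing measured here explains these numbers.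

The compounds shown leave open how 1-propyl-1H-imidazol-4-yl, carrying no methyl, would compare. They also leave open what a butyl chain in place of the propyl, or a phenyl in place of the imidazole, would give.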